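The compounds below may be only part of what the source reports. "The series", "measured", "known", "first", "only" and "open" are said of these compounds alone.

Working notes on the series. Three compounds share one core and differ only at a saturated ring carbon of the six-membered carbon-only ring. In an assay on isolated protein for binding affinity to Gonadotropin-releasing hormone receptor (Rattus norvegicus) (on this read-out lower numbers stand for stronger inhibition and higher numbers for weaker inhibition), compound 1 `Cc1cc2c(cc1Cc1ccc(C(=O)NCC3CCCCC3)o1)C(C)(C)CCC2(C)C` gives 1550 nM, which is the second highest of the three numbers. Compound 2 `Cc1cc2c(cc1Cc1ccc(C(=O)NC[C@H]3CC[C@H](C(N)=O)CC3)o1)C(C)(C)CCC2(C)C` gives 270 nM in this assay, and compound 3 `Cc1cc2c(cc1Cc1ccc(C(=O)NC[C@H]3CC[C@H](C(=O)O)CC3)o1)C(C)(C)CCC2(C)C` gives 3000 nM. The measured steps are a 5.7-fold lower number from compound 1 to compound 2 (0.76 log units; beyond the scatter), a 1.9-fold higher number from compound 1 to compound 3 (0.29 log units; within the scatter) and an 11-fold higher number from compound 2 to compound 3 (1.05 log units; beyond the scatter).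

Compound 4 `Cc1cc2c(cc1Cc1ccc(C(=O)NCC3CCC(CNCc4cc(O)nc(O)n4)CC3)o1)C(C)(C)CCC2(C)C` has not yet been measured in this assay. It differs from compound 1 by (((2,6-dihydroxypyrimidin-4-yl)methyl)amino)methyl in place of hydrogen on a saturated ring carbon. Among the measured compounds shown here, the steps that bear on this change are the two additions at the same ring carbon: the modest gain in a 5.7-fold lower number from compound 1 to compound 2 (0.76 log units; beyond the scatter) and the change within the scatter in a 1.9-fold higher number from compound 1 to compound 3 (0.29 log units; within the scatter). The incoming group is much larger than either carbamoyl or carboxy, so those steps guide only loosely; a small to modest lowering of the number in this assay is expected for compound 4, since the uncharged donor-bearing carbamoyl in a 5.7-fold lower number from compound 1 to compound 2 (0.76 log units; beyond the scatter) improved on compound 1 whereas the acid did not. The estimated step is a 2.2-fold lower number from compound 1 to compound 4 (0.35 log units; beyond the scatter). Compound 4 is expected to give about 700 nM in this assay, with a likely range from 200 nM to 2500 nM.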

Compound 4, inhibition constant: 865 nM
Compound 4: the middle estimate sits 1.2-fold (0.09 log units) below what was measured, and the stated range covers the measured number.
By their numbers in this assay, from the lowest: compound 2; then compounds 4, 1 and 3 (each within the scatter of the next, the first and the last beyond it).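

Adding (((2,6-dihydroxypyrimidin-4-yl)methyl)amino)methyl at the saturated ring carbon gives a 1.8-fold lower number from compound 1 to compound 4 (0.25 log units; within the scatter) in this assay, so this position takes a group much larger than carbamoyl or carboxy, one bearing a six-membered aromatic ring, with no change beyond the scatter. The gain beyond the scatter seen in a 5.7-fold lower number from compound 1 to compound 2 (0.76 log units; beyond the scatter) therefore does not extend to this larger group, and a substituent that is uncharged and carries donors is not enough on its own to give such a gain here. No measured evidence is available to account for this result.

The compounds shown leave open which part of the incoming group governs the read-out, since neither a simple aminomethyl group nor a benzylaminomethyl group is among them. A methyl ester or a longer chain ending in carbamoyl at the same ring carbon would also test how specific the carbamoyl step is.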